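Replacing the Hydroxy-Ether Chain of Compound 1 with Carboxy

This account rests on a few compounds, and the source may have more. Where it says the series, first, only, none or still open, it means among the compounds named here.

Compound 1, `O=c1c(-c2ccc(O)cc2)coc2cc(OCCOCCOCCO)ccc12`, in an assay (Cricetulus griseus) for inhibition of aldehyde dehydrogenase, mitochondrial (Homo sapiens); on this read-out lower numbers stand for stronger inhibition and higher numbers for weaker inhibition: 40 nM
Compound 2, `O=c1c(-c2ccc(O)cc2)coc2cc(OCCCCCCCCCO)ccc12`, in this assay: 700 nM
Compound 3, `CC(Oc1ccc2c(=O)c(-c3ccc(O)cc3)coc2c1)C(=O)O`, in this assay: 2500 nM

Within the data shown here, compound 1 stands lowest of the three numbers so far. Its nearest neighbour is compound 2, reached by an 18-fold higher number from compound 1 to compound 2 (1.24 log units; beyond the scatter), and its furthest is compound 3, reached by a 63-fold higher number from compound 1 to compound 3 (1.80 log units; beyond the scatter); both steps are large and both lie beyond the usual scatter, so every change made so far to the chain on the shared core has weakened inhibition.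

Compound 4, `O=C(O)COc1ccc2c(=O)c(-c3ccc(O)cc3)coc2c1`, has not yet been measured. It differs from compound 1 in one place: carboxy in place of (2-(2-hydroxyethoxy)ethoxy)methyl on a saturated chain carbon bound to an oxygen on an aromatic ring.

Among the measured compounds shown here, of the two measured steps, the one from compound 1 to compound 3 bears most directly on this, since compound 3 also carries a carboxylic acid where the long hydroxy-ether chain of compound 1 stood, and that step was large, a 63-fold higher number from compound 1 to compound 3 (1.80 log units; beyond the scatter). The step to compound 2 shows that even keeping a long chain with a hydroxyl end does not preserve the number of compound 1. Compound 4 is therefore expected to give a clearly higher number in this assay, a step of about a 50-fold higher number from compound 1 to compound 4 (1.70 log units; beyond the scatter). The estimate for compound 4 is 2000 nM, with a range from 600 nM to 6000 nM.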

Compound 4, half-maximal inhibitory concentration: 1200 nM
Compound 4: middle estimate off by 1.7-fold (0.22 log units), on the high side, and the stated range covers the measured number.
By their numbers in this assay, from the lowest: compound 1; then compounds 2 and 4 (each within the scatter of the next); then compound 3.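

In this assay, the result shows that the low number of compound 1 is also lost when the chain is cut back to a carboxymethyl group with no branch (a step of a 30-fold higher number from compound 1 to compound 4 (1.48 log units; beyond the scatter)), so the loss seen with compound 3 does not depend on its methyl group. That methyl group has only a modest effect of its own (a step of a 2.1-fold lower number from compound 3 to compound 4 (0.32 log units; beyond the scatter)), small beside the large step away from compound 1. The short acid and the long alcohol chain also give numbers that cannot be told apart (a step of a 1.7-fold higher number from compound 2 to compound 4 (0.23 log units; within the scatter)), so two quite different replacements for the hydroxy-ether chain end at much the same level, and neither comes close to compound 1. Nothing available here explains these differences.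

The compounds shown leave open whether the chain length or the end group matters more, since a carboxylic acid at the end of the full-length ether chain would separate the two. They also leave open whether a short chain ending in a hydroxyl, an amine or a methyl ester would behave like compound 4 or move back towards compound 1.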